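Reversing the benzimidazole-for-carbamoyl step in the series

The compounds below may be only part of what the source reports. "The series", "measured", "known", "first", "only" and "open" are said of these compounds alone.

Among the measured compounds shown here, in an ADME assay on MT4 cells (Homo sapiens) for cytotoxicity, read by MTT assay (on this read-out lower numbers stand for higher toxicity in this test and higher numbers for lower toxicity in this test), compound 3 `Cc1cc(C)cc(S(=O)(=O)c2c(C(=O)NCc3ccc4nc(N)[nH]c4c3)[nH]c3ccc(Cl)cc23)c1` gives 5890 nM, the only number among the three values shown. Compound 1 `Cc1cc(C)cc(S(=O)(=O)c2c(C(=O)NC(c3ccc(Cl)cc3)C3CC3)[nH]c3ccc(Cl)cc23)c1` sits at a limit of this assay, > 47300 nM. Compound 2 `Cc1cc(C)cc(S(=O)(=O)c2c(C(=O)NCC(=O)NCc3ccncc3)[nH]c3ccc(Cl)cc23)c1` likewise sits at a limit, > 48900 nM. Two measured steps lead to the same end point: an at least 8.0-fold lower number from compound 1 to compound 3 (0.90 log units; beyond the scatter) and an at least 8.3-fold lower number from compound 2 to compound 3 (0.91 log units; beyond the scatter); their sizes rest on the limit of > 47300 nM in this assay, at which 1 of the 3 values shown sits, and (the limit of > 48900 nM in this assay, at which 1 of the 3 values shown sits), so both are lower bounds.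

Compound 4 `Cc1cc(C)cc(S(=O)(=O)c2c(C(=O)NCC(=O)NCc3ccncn3)[nH]c3ccc(Cl)cc23)c1` carries the change (((pyrimidin-4-yl)methyl)carbamoyl in place of 2-amino-1H-benzimidazol-6-yl on a saturated chain carbon bound to an amide-type nitrogen). This removes the group that distinguishes compound 3 and installs a ((pyrimidin-4-yl)methyl)carbamoyl closely resembling the group of compound 2, so the step of an at least 8.3-fold lower number from compound 2 to compound 3 (0.91 log units; beyond the scatter) bears on it in reverse. A higher number is therefore expected in this assay, about as large as that step, and the result is expected to fall at or near a limit of this assay rather than as a number. For compound 4 the estimate in this assay is 48000 nM, with a range of 15000 nM to 120000 nM. For compound 4 this corresponds to an expected step of an 8.1-fold higher number from compound 3 to compound 4 (0.91 log units; beyond the scatter).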

Compound 4, half-maximal cytotoxic concentration: > 48800 nM
Compound 4 gave a limit, no number; the forecaster's own chance of this, stated with the estimate: 70%; middle value at least 1.0-fold (0.00 log units) from the limit.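

At the saturated chain carbon bound to an amide-type nitrogen, a second carbamoyl group now gives the same outcome as in compound 2 in this assay: with ((pyrimidin-4-yl)methyl)carbamoyl in place of 2-amino-1H-benzimidazol-6-yl, the result is an at least 8.2-fold higher number from compound 3 to compound 4 (0.91 log units; beyond the scatter). Compound 4 ends at a limit, as compound 2 does, so pyrimidin-4-yl in place of pyridin-4-yl brings no measurable toxicity in this test up to that limit. The steps from compound 1 and from compound 2 to compound 4 cannot be read, and the step from compound 3 is only a lower bound set by a limit: the limit of > 48800 nM in this assay, at which 1 of the 4 values shown sits.

As far as these compounds go, it remains open whether the lower number of compound 3 follows the amine of the 2-amino-1H-benzimidazol-6-yl or the rest of that group; a 1H-benzimidazol-6-yl without the amine at the same place would separate the two. From the compounds shown here alone, how compound 1, compound 2 and compound 4 order among themselves also remains open.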